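The compounds below may be only part of what the source reports. "The series", "measured", "known", "first", "only" and "open" are said of these compounds alone.

In a functional assay on HT-1080 cells (Homo sapiens) for cytotoxicity, read by MTT assay, with a stated time of 72 h (a lower number here means a stronger inhibitor, a higher number a weaker inhibitor), two compounds built on a shared core have been measured so far. Compound 1 `COc1cccc(/C=C2\CCC/C(=C\c3cccc(O)c3)C2=O)c1OC` gives 8500 nM, and compound 2 `COc1cccc(/C=C2\CCC/C(=C\c3ccc(Cl)c(Cl)c3)C2=O)c1OC` gives 10800 nM. These two numbers lie within the usual scatter of each other, so compound 2 stands level with compound 1 and neither can be ranked ahead of the other. Compound 3 `COc1cccc(/C=C2\CCC/C(=C\c3cc(Cl)cc(Cl)c3)C2=O)c1OC` keeps the same core and differs from compound 2 in one group, with 3,5-dichlorophenyl in place of 3,4-dichlorophenyl on a double-bonded chain carbon bound to a double-bonded ring carbon. The swap sits on a double-bonded chain carbon bound to a double-bonded ring carbon. Among the compounds with values here, only one measured step bears on it, the replacement of 3-hydroxyphenyl by 3,4-dichlorophenyl at that same place: a 1.3-fold higher number from compound 1 to compound 2 (0.10 log units; within the scatter). That single step stayed within the scatter, and it is thin evidence, so no step beyond the scatter is expected in this assay, in either direction. The expected step is a 1.1-fold lower number from compound 2 to compound 3 (0.03 log units; within the scatter). The estimate for compound 3 is 10000 nM, with an expected range from 4000 nM to 25000 nM.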

Compound 3, half-maximal inhibitory concentration: 6100 nM
Estimate against measurement, compound 3: 1.6-fold (0.21 log units) above; the range from low to high includes it.
By their numbers in this assay, from the lowest: compounds 3, 1 and 2 (each within the scatter of the next).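

Going from 3,4-dichlorophenyl to 3,5-dichlorophenyl keeps the same atoms and only joins them differently, and in this assay this gives a 1.8-fold lower number from compound 2 to compound 3 (0.25 log units; within the scatter) for the change. This position on a double-bonded chain carbon bound to a double-bonded ring carbon has therefore now met a rearranged chlorine pattern as well as an exchange of one group for another, and neither moved the number beyond the scatter. The direct exchange of 3-hydroxyphenyl for 3,5-dichlorophenyl agrees, with a 1.4-fold lower number from compound 1 to compound 3 (0.14 log units; within the scatter) as its step, so the three groups at this place cannot be told apart in this measurement, and nothing else available on these compounds bears on the result.

From the compounds shown here alone, all three groups are phenyl rings carrying hydroxyl or chlorine, so it remains open whether an amine, a carboxylic acid or a longer chain at this place would shift the number beyond the scatter. Every change shown also sits at this one place, and what a change elsewhere on the shared core would do stays open too.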